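The source may hold more compounds than are shown below. What is called first, only, known or untested is meant among the compounds shown, and "the series" means these compounds.

In an ADME assay on NIH3T3 cells (Mus musculus) for cytotoxicity (on this read-out lower numbers stand for an effect already at smaller amounts and higher numbers for an effect only at larger amounts of compound), compound 1 `Cc1cc(Oc2cccc(Cn3ccnn3)c2)cc(C)c1Cl` gives 66800 nM and compound 2 `Cc1nnc(-c2cccc(Oc3cc(C)c(Cl)c(C)c3)c2)o1` gives 46100 nM while compound 3 `Cc1nnc(Cc2cccc(Oc3cc(C)c(Cl)c(C)c3)c2)o1` gives 6200 nM and so holds the lowest number of the three. The next compound to be read is compound 4 `Cc1nnc(-c2cccc(Oc3cc(C)c(Cl)c(C)c3)c2)s1` which differs from compound 3 by this change: 5-methyl-1,3,4-thiadiazol-2-yl in place of (5-methyl-1,3,4-oxadiazol-2-yl)methyl on an aromatic carbon. The five-membered ring then stands on an aromatic carbon with no saturated chain carbon, as it does in compound 2.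

The closest measured evidence is a 7.4-fold lower number from compound 2 to compound 3 (0.87 log units; beyond the scatter) where that chain carbon enters, and the move to compound 4 runs the opposite way. The pattern is not general: compound 1 also carries a saturated chain carbon, yet a 1.4-fold lower number from compound 1 to compound 2 (0.16 log units; within the scatter) stays within the scatter, while an 11-fold lower number from compound 1 to compound 3 (1.03 log units; beyond the scatter) shows how far the ring attached through the chain carbon can matter. Within the data shown here, no measured step shows a thiadiazole taking the place of an oxadiazole, so that part of the change remains open. A partial return toward compound 2 is therefore expected. The step expected in this assay is a 4.8-fold higher number from compound 3 to compound 4 (0.68 log units; beyond the scatter) toward a higher number. Compound 4 is thus expected at 30000 nM within an estimated range of 11000 nM to 75000 nM on this read-out.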

Compound 4, half-maximal effective concentration: > 100000 nM
Compound 4 gave a limit, no number; the forecaster's own chance of this, stated with the estimate: 15%; at least 3.3-fold (0.52 log units) between middle value and limit.
By their numbers in this assay, from the lowest: compound 3; then compounds 2 and 1 (each within the scatter of the next). At a limit, above all of these: compound 4.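

In this assay the reading of compound 4 is a limit of the assay and not a number: the limit of > 100000 nM in this assay, at which 1 of the 4 values shown sits. Without the saturated chain carbon the change is large, with an at least 16-fold higher number from compound 3 to compound 4 (1.20 log units; beyond the scatter) on record, and this sets the thiadiazole on the aromatic carbon, meta to a large group, clearly apart from the chain-linked oxadiazole. The earlier compounds shown here held no direct exchange of one ring for the other, and now an at least 2.1-fold higher number from compound 2 to compound 4 (0.33 log units; beyond the scatter) shows that 5-methyl-1,3,4-thiadiazol-2-yl in place of 5-methyl-1,3,4-oxadiazol-2-yl moves the reading upward beyond the scatter, while an at least 1.4-fold higher number from compound 1 to compound 4 (0.17 log units; that floor lies within the scatter) has a floor within the scatter and so fixes no order for that pair.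

As far as these compounds go, the true size of all three steps stays unknown, since each rests on a limit, and whether a saturated chain carbon would lower the number with the thiadiazole as it does with the oxadiazole remains open. Also open, from the compounds shown here alone, is what an amine in place of the methyl group on the five-membered ring would do at this place.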